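This account rests on a few compounds, and the source may have more. Where it says the series, first, only, none or still open, it means among the compounds named here.

Within the data shown here, compound 2 `O=C(NC[C@H]1CN(c2ccc(-n3cc(-c4ccccn4)cn3)c(F)c2)C(=O)O1)C(F)F` gives 1.9 in a physicochemical assay for lipophilicity, read by HPLC, measured as octanol-water partition (a lower number here means a more polar compound, a higher number a more lipophilic compound), the higher of the two numbers so far, while compound 1 `CN(C)S(=O)(=O)NC[C@H]1CN(c2ccc(-n3cc(-c4ccccn4)cn3)c(F)c2)C(=O)O1` gives 1.38. Among the measured compounds shown here, the only measured step, a number 0.52 log units higher from compound 1 to compound 2 (beyond the scatter), concerns a quite different exchange and so bears only loosely on the next one. Compound 3 `O=C1O[C@@H](CNC(=O)C(F)(F)F)CN1c1ccc(-n2cc(-c3ccccn3)cn2)c(F)c1` differs from compound 2 by fluoro in place of hydrogen on a saturated chain carbon bound to a carbonyl carbon and two fluorine atoms. For the measured compounds named here, with no measured step of this kind to lean on, a small upward shift is the expectation. The expected step is a number 0.40 log units higher from compound 2 to compound 3 (beyond the scatter). Compound 3 is therefore estimated at 2.3, with a range of 1.9 to 2.7.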

Compound 3, partition coefficient: >= 1.78
Compound 3: only a limit was reported; the forecaster's own chance of this, stated with the estimate: 2%; the middle value does not contradict the limit.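

Compound 3 gives only a limit in this assay: the limit of >= 1.78 in this assay, at which 1 of the 3 values shown sits.

On these data alone, the step from difluoromethyl to trifluoromethyl therefore cannot be read, and the size of this fluoro in place of hydrogen stays unknown. On an amine nitrogen, (trifluoromethyl)carbonyl in place of dimethylsulfamoyl still gives a number at least 0.40 log units higher from compound 1 to compound 3 (beyond the scatter), in the same direction as the (difluoromethyl)carbonyl exchange.

As far as these compounds go, whether the added fluoro moves the number at all remains open. Also open, from the compounds shown here alone, is where a plain acetyl group or a longer chain such as pentafluoroethylcarbonyl on that nitrogen would fall.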